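The source may hold more compounds than are shown below. What is called first, only, known or untested is meant among the compounds shown, and "the series" means these compounds.

Measured so far in an ADME assay on microsomes from liver (Homo sapiens) for pharmacokinetics, read by LC-MS, with a stated time of 60 min, tested at 1 uM; a higher number here means faster removal of the compound, a lower number slower removal:

- compound 1 `O=C(NCc1ccc(S(=O)(=O)c2cncc(C(F)(F)F)c2)cc1)N1Cc2ccncc2C1`: 13 mL/min/kg
- compound 2 `CC(C)n1cc(S(=O)(=O)c2ccc(CNC(=O)N3Cc4ccncc4C3)cc2)cn1`: 4 mL/min/kg
- compound 3 `CC(=O)N1CCC(S(=O)(=O)c2ccc(CNC(=O)N3Cc4ccncc4C3)cc2)CC1`: 6 mL/min/kg

Compound 3, at 6 mL/min/kg, holds the second highest of the three numbers. The gap to compound 1 is a real one, a 2.2-fold lower number from compound 1 to compound 3 (0.34 log units; beyond the scatter), while the gap to compound 2 is not, a 1.5-fold higher number from compound 2 to compound 3 (0.18 log units; within the scatter).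

The next compound is compound 4 `O=C(NCc1ccc(S(=O)(=O)N2CCC[C@H](O)C2)cc1)N1Cc2ccncc2C1`, which carries 3-hydroxypiperidin-1-yl in place of 1-acetylpiperidin-4-yl on a sulfonyl sulfur.

All three measured steps change the group at this same place. The two that start from compound 1 are modest, a 3.3-fold lower number from compound 1 to compound 2 (0.51 log units; beyond the scatter) and a 2.2-fold lower number from compound 1 to compound 3 (0.34 log units; beyond the scatter). The third, a 1.5-fold higher number from compound 2 to compound 3 (0.18 log units; within the scatter), shows that two quite different groups can give values within the scatter of each other. Among the compounds with values here, none of the measured compounds carries 3-hydroxypiperidin-1-yl, so the data give no direct guide to its effect, and no direction can be claimed with confidence in this assay.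

The expected change is small, a 1.2-fold lower number from compound 3 to compound 4 (0.08 log units; within the scatter), and is not expected to exceed the scatter. For compound 4 the estimated value is 5 mL/min/kg, with an expected range from 2.5 mL/min/kg to 11 mL/min/kg.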

Compound 4, clearance: 8 mL/min/kg
Compound 4: the middle estimate sits 1.6-fold (0.20 log units) below what was measured; low and high end bracket the measured number.
By their numbers in this assay, from the lowest: compounds 2, 3, 4 and 1 (each within the scatter of the next, the first and the last beyond it).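

In this assay, within the data shown here, 3-hydroxypiperidin-1-yl is the first group on this sulfonyl sulfur to carry a hydrogen-bond donor and a defined stereocentre, yet compound 4 stays within the scatter of all three earlier compounds: a 1.3-fold higher number from compound 3 to compound 4 (0.12 log units; within the scatter), a 2.0-fold higher number from compound 2 to compound 4 (0.30 log units; within the scatter) and a 1.6-fold lower number from compound 1 to compound 4 (0.21 log units; within the scatter). Compound 4 therefore separates from neither compound 1 nor compound 2, even though those two compounds are separated from each other, with a 3.3-fold lower number from compound 1 to compound 2 (0.51 log units; beyond the scatter), so this change opens no readable gap at this position. Nothing among the data shown explains where compound 4 falls, and no cause can be assigned to this result.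

The compounds shown leave open whether the hydroxyl group or its stereocentre matters at all, since neither plain piperidin-1-yl nor the opposite stereoisomer of 3-hydroxypiperidin-1-yl appears among them. They also leave open whether a morpholin-4-yl group, or a piperidine ring bearing a carboxylic acid or a primary amine, on this sulfonyl sulfur would give a step beyond the scatter from compound 4.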